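A few compounds are considered here, and "the series" means these few. Any claim that something is new, unique, unknown or untested is made for them only; others in the source may bear on it.

Compound 1 `CNC(=O)c1cc(-c2cnc(NCc3c(F)ccc4c3CCO4)c3cn[nH]c(=O)c23)n(C)n1` gives < 3 mL.min-1.g-1 in an ADME assay on microsomes from liver (Homo sapiens) for metabolic stability, read by LC-MS, using NADPH, with stated times of 5 min and 30 min, tested at 1 uM; on this read-out lower numbers stand for slow clearance and higher numbers for fast clearance.
Compound 2 `CN(c1ccccc1)c1cnc(NCc2c(F)ccc3c2CCO3)n2cnnc12` gives 55 mL.min-1.g-1 in this assay.
Compound 3 `CN(c1ccn(C)n1)c1cnc(NCc2c(F)ccc3c2CCO3)n2cnnc12` gives 11 mL.min-1.g-1 in this assay.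

Compound 1 stands at the limit of < 3 mL.min-1.g-1 in this assay, at which 1 of the 3 values shown sits, a limit of the assay rather than a number. Compound 4 `Cc1nc(CO)ccc1-c1cnc(NCc2c(F)ccc3c2CCO3)c2cn[nH]c(=O)c12` differs from it by 6-(hydroxymethyl)-2-methylpyridin-3-yl in place of 1-methyl-3-(methylcarbamoyl)-1H-pyrazol-5-yl on an aromatic carbon. Among the measured compounds shown here, the one measured step on a different core, a 5.0-fold lower number from compound 2 to compound 3 (0.70 log units; beyond the scatter), shows that swapping one aromatic group for another can move this assay by a modest amount, with the five-membered ring giving the lower number. Compound 4 trades a five-membered aromatic ring for a six-membered one, so a step of similar size in the upward direction is expected, though compound 1 at its limit leaves the starting point uncertain. Compound 4 is therefore estimated at 6 mL.min-1.g-1, between 2 mL.min-1.g-1 and 18 mL.min-1.g-1, an expected step of an at least 2.0-fold higher number from compound 1 to compound 4 (0.30 log units; that floor lies within the scatter).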

Compound 4, intrinsic clearance in microsomes: 11 mL.min-1.g-1
Compound 4: middle estimate off by 1.8-fold (0.26 log units), on the low side; low and high end bracket the measured number.
By their numbers in this assay, from the lowest: compounds 3 and 4 (each within the scatter of the next); then compound 2. At a limit, below all of these: compound 1.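

On the core of compound 1, the group on this aromatic carbon, para to a large group, clearly moves the read-out: 6-(hydroxymethyl)-2-methylpyridin-3-yl in place of 1-methyl-3-(methylcarbamoyl)-1H-pyrazol-5-yl gives an at least 3.6-fold higher number from compound 1 to compound 4 (0.56 log units; beyond the scatter) in this assay. The value of compound 1 is a limit and not a number, so this step gives only a floor: the limit of < 3 mL.min-1.g-1 in this assay, at which 1 of the 4 values shown sits.

Still open, on these data alone, is which part of the exchange carries the step: the six-membered aromatic ring, the hydroxymethyl or the methyl. Also open, as far as these compounds go, is how an amine or a longer chain in place of the hydroxymethyl would read.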